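A few compounds are considered here, and "the series" means these few. Any claim that something is new, unique, unknown or untested is made for them only; others in the source may bear on it.

In an ADME assay (liver) for metabolic stability, with Liver microsome (Rattus norvegicus) as the target, using microsomes and NADPH, with a stated time of 30 min, tested at 1 uM (on this read-out lower numbers stand for slow clearance and higher numbers for fast clearance), three compounds sharing one core have been measured. Compound 1 `Nc1ccc(S(=O)(=O)N2CCN(c3ncc(C(O)(C(F)(F)F)C(F)(F)F)cc3C3CC3)CC2)cn1` gives 27 mL.min-1.g-1 and compound 2 `COCC#Cc1cc(C(O)(C(F)(F)F)C(F)(F)F)cnc1N1CCN(S(=O)(=O)c2ccc(N)nc2)CC1` gives 399 mL.min-1.g-1 on this scale. Compound 3 `Nc1ccc(S(=O)(=O)N2CCN(c3ncc(C(O)(C(F)(F)F)C(F)(F)F)cc3-c3ccccc3O)CC2)cn1` gives 125 mL.min-1.g-1 and so stands in the middle of the three. Compound 4 `Nc1ccc(S(=O)(=O)N2CCN(c3ncc(C(O)(C(F)(F)F)C(F)(F)F)cc3-c3cccnc3)CC2)cn1` differs from compound 3 at a single place (pyridin-3-yl in place of 2-hydroxyphenyl on an aromatic carbon), with pyridin-3-yl in place of 2-hydroxyphenyl on an aromatic carbon. The measured steps at this same carbon are the guide: a 4.6-fold higher number from compound 1 to compound 3 (0.67 log units; beyond the scatter) is modest, a 3.2-fold lower number from compound 2 to compound 3 (0.50 log units; beyond the scatter) is also modest, and a 15-fold higher number from compound 1 to compound 2 (1.17 log units; beyond the scatter) is large. Among the measured compounds, only compound 3 (125 mL.min-1.g-1) carries a six-membered aromatic ring at this carbon, so it is the closest guide. Within the data shown here, no measured compound carries pyridin-3-yl, so the data give no direction, and no step beyond the scatter is expected. The expected step is small (a 1.3-fold lower number from compound 3 to compound 4 (0.10 log units; within the scatter)) but uncertain. For compound 4 the estimated value in this assay is 100 mL.min-1.g-1 (expected range 35 mL.min-1.g-1 to 280 mL.min-1.g-1).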

Compound 4, intrinsic clearance in microsomes: 20 mL.min-1.g-1
The estimate for compound 4 lay 5.0-fold (0.70 log units) above the measured number, and the stated range ends above it.
By their numbers in this assay, from the lowest: compounds 4 and 1 (each within the scatter of the next); then compound 3; then compound 2.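

In this assay the result shows that having a six-membered aromatic ring at this carbon does not settle the number, since pyridin-3-yl in place of 2-hydroxyphenyl gives a 6.3-fold lower number from compound 3 to compound 4 (0.80 log units; beyond the scatter) and so the identity of the ring matters. Pyridin-3-yl also gives a 20-fold lower number from compound 2 to compound 4 (1.30 log units; beyond the scatter) when it replaces 3-methoxyprop-1-yn-1-yl, yet a 1.4-fold lower number from compound 1 to compound 4 (0.13 log units; within the scatter) when it replaces cyclopropyl, so an aromatic ring here can sit level with cyclopropyl on this read-out. Nothing available explains these differences.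

The step from compound 3 to compound 4 removes a hydroxyl group and brings in a ring nitrogen together, so the two changes cannot be told apart. Plain phenyl at this carbon would separate them, and pyridin-4-yl would test whether the place of the ring nitrogen matters.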